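Removing a fluorine from an already inactive triazole series

The compounds below may be only part of what the source reports. "The series", "measured", "known", "first", "only" and "open" are said of these compounds alone.

Three measured compounds share one core and differ only in the group on the phenyl ring of the triazole. Compound 1, `C=C1C[C@]23C[C@@]1(O)CC[C@H]2c1ccc(OS(=O)(=O)c2ccc(C)cc2)c(C)c1[C@@H]3Cn1cc(-c2ccc(Br)cc2)nn1`, carries bromo there. In a functional assay on SW480 cells (Homo sapiens) for cytotoxicity, read by MTT assay, with a stated time of 4 days (a higher number here means a weaker inhibitor, a lower number a stronger inhibitor), compound 1 gives no number but only a limit, > 20000 nM. Compound 2, `C=C1C[C@]23C[C@@]1(O)CC[C@H]2c1ccc(OS(=O)(=O)c2ccc(C)cc2)c(C)c1[C@@H]3Cn1cc(-c2ccc(OC)cc2)nn1`, carries methoxy, and in this assay compound 2 also reaches only a limit, > 20000 nM. Compound 3, `C=C1C[C@]23C[C@@]1(O)CC[C@H]2c1ccc(OS(=O)(=O)c2ccc(C)cc2)c(C)c1[C@@H]3Cn1cc(-c2ccc(F)cc2)nn1`, carries fluoro, and in this assay compound 3 shows the same limit, > 20000 nM. Because (the limit of > 20000 nM in this assay, at which 3 of the 3 values shown sit), the steps a step that the two limits leave unreadable from compound 1 to compound 2, a step that the two limits leave unreadable from compound 1 to compound 3 and a step that the two limits leave unreadable from compound 2 to compound 3 cannot be read in size or direction. So compound 3 stands nowhere distinct: it sits at the same limit as the two others.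

Compound 4, `C=C1C[C@]23C[C@@]1(O)CC[C@H]2c1ccc(OS(=O)(=O)c2ccc(C)cc2)c(C)c1[C@@H]3Cn1cc(-c2ccccc2)nn1`, arises from compound 3 by hydrogen in place of fluoro on an aromatic carbon. Within the data shown here, no measured step bears on this change in a readable way, as every change on this ring so far left the value at the limit. The expectation is therefore no step beyond the scatter, with a step that the limit leaves unreadable from compound 3 to compound 4 as the estimated change. Compound 4 is expected to give about 25000 nM in this assay, within a range from 8000 nM to 80000 nM, most likely again reported only as a limit.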

Compound 4, half-maximal inhibitory concentration: > 20000 nM
Compound 4 was reported as a limit; the forecaster's own chance of this, stated with the estimate: 85%; the middle value is on the limit's open side.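

Compound 4 also gives a limit rather than a number, so its steps from compound 1, compound 2 and compound 3 cannot be read in size or direction, because all four compounds end at the same point: the limit of > 20000 nM in this assay, at which 4 of the 4 values shown sit. The compounds shown leave open how strong each one really is in this assay, and whether the group on this phenyl ring matters at all.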